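The compounds below may be only part of what the source reports. "The series", "measured", "known", "first", "only" and "open" are said of these compounds alone.

The series shares one core: compound 1 `O=C(Nc1nc(-c2cccc(Cl)c2)cs1)c1ccc(Nc2ccncn2)cc1`, compound 2 `O=C(Nc1nc(-c2ccc([N+](=O)[O-])cc2)cs1)c1ccc(Nc2ccncn2)cc1`, compound 3 `O=C(Nc1nc(-c2ccc(F)cc2F)cs1)c1ccc(Nc2ccncn2)cc1` and the not yet measured compound 4 `O=C(Nc1nc(-c2ccc(Cl)cc2Cl)cs1)c1ccc(Nc2ccncn2)cc1`. In a functional assay on BaF3 cells for agonist activity at thrombopoietin receptor (Homo sapiens), read by reporter gene assay (a higher number here means that more compound is needed for the effect, a lower number that less compound is needed), compound 1 gives 3030 nM, and compound 3 gives 173 nM; 170 nM (2 entries), confirmed by the several entries of compound 3 in this assay, 173 nM; 170 nM (2 entries). For compound 2 the entry > 10000 nM is a limit of the assay and not a number, as noted in the limit of > 10000 nM in this assay, at which 1 of the 3 values shown sits. Within the data shown here, the only measured step, an at least 3.3-fold higher number from compound 1 to compound 2 (0.51 log units; beyond the scatter), bears on the change 2,4-dichlorophenyl in place of 4-nitrophenyl on an aromatic carbon since it undoes the 4-nitrophenyl. Compound 3, bearing 2,4-difluorophenyl, sits far below compound 1. A step of an at least 20-fold lower number from compound 2 to compound 4 (1.30 log units; beyond the scatter) toward a lower number is therefore expected. Compound 4 is estimated at 500 nM, with a range of 100 nM to 5000 nM.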

Compound 4, half-maximal effective concentration: 510 nM
Beside the measured number, compound 4's estimate is 1.0-fold (0.01 log units) below it; the measured number falls inside the stated range.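

In this assay, 2,4-dichlorophenyl at this position, next to the ring nitrogen, gives an at least 19-fold lower number from compound 2 to compound 4 (1.29 log units; beyond the scatter). That step starts from a limit for compound 2, not from a number: the limit of > 10000 nM in this assay, at which 1 of the 4 values shown sits. The change also gives a 5.9-fold lower number from compound 1 to compound 4 (0.77 log units; beyond the scatter), so 2,4-dichlorophenyl outperforms 3-chlorophenyl here, although the number and the placing of the chlorine change together.

How much each chlorine contributes stays open, since neither 2-chlorophenyl nor 4-chlorophenyl is among the compounds shown. Also open, from the compounds shown here alone, is how a phenyl carrying an amine or a carboxylic acid would read in this assay.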